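Swapping Nitro for Methylsulfonyl on Two Related Cores

The source may report more compounds than this note shows. Statements on the series, on what has been measured and on what is new or still open speak of the compounds shown alone.

Of the compounds shown here, three have so far been measured in a physicochemical assay for solubility, read by spectrophotometry, in phosphate buffer, with a stated time of 18 h, at pH 7.4; on this read-out lower numbers stand for lower solubility and higher numbers for higher solubility. Compound 1 `CCc1ccc(-c2nc3c(c(C)nn3-c3ccccc3)c(-c3ccccc3[N+](=O)[O-])c2C#N)cc1` gives 1200 nM, and compound 2 `CCc1ccc(-c2nc3c(c(C)nn3-c3ccccc3)c(-c3ccccc3S(C)(=O)=O)c2C#N)cc1` gives 2200 nM. Compound 2 differs from compound 1 in a single spot: methylsulfonyl in place of nitro on an aromatic carbon. That change made a step of a 1.8-fold higher number from compound 1 to compound 2 (0.26 log units; within the scatter). Compound 3 `Cc1nn(-c2ccccc2)c2nc(-c3ccc([N+](=O)[O-])cc3)c(C#N)c(-c3ccccc3O)c12` is built on a different core, and the difference between the two cores is not broken down here; in this assay compound 3 gives 6000 nM, the highest of the three numbers. Compound 4 `Cc1nn(-c2ccccc2)c2nc(-c3ccc(S(C)(=O)=O)cc3)c(C#N)c(-c3ccccc3O)c12` has not yet been measured. It differs from compound 3 as follows: methylsulfonyl in place of nitro on an aromatic carbon. For the measured compounds named here, this is the same kind of change as the one between compound 1 and compound 2, but the surroundings differ: in compound 1 the group sits ortho to a large group, whereas in compound 3 it sits para to a large group. Because a 1.8-fold higher number from compound 1 to compound 2 (0.26 log units; within the scatter) stayed within the scatter, a similarly small step, a 1.5-fold higher number from compound 3 to compound 4 (0.18 log units; within the scatter), is expected for compound 4. Compound 4 is therefore estimated at 9000 nM, most likely between 4000 nM and 20000 nM.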

Compound 4, solubility: 5000 nM
Beside the measured number, compound 4's estimate is 1.8-fold (0.26 log units) above it, and the stated range covers the measured number.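

In this assay the swap of nitro for methylsulfonyl gives a 1.2-fold lower number from compound 3 to compound 4 (0.08 log units; within the scatter) and, on the core of compound 1, it gave a 1.8-fold higher number from compound 1 to compound 2 (0.26 log units; within the scatter) so on both cores the step stays within the usual scatter of repeated measurements. For the compounds shown here, the two steps point in opposite directions, but neither can be told apart from that scatter, so this shows no real reversal between the cores and only that neither pair reveals a clear effect of the swap; two pairs cannot establish a rule for the whole series. Nothing measured here speaks to why the numbers fall as they do.

As far as these compounds go, what stays open is whether the same quiet result would hold on other cores, or with the group placed elsewhere on the ring. From the compounds shown here alone, it is equally open how an amine or a carboxylic acid in place of methylsulfonyl on the 4-(methylsulfonyl)phenyl ring would read in this measurement.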